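Compound 3 to compound 4: methoxy in place of methyl

The source may report more compounds than this note shows. Statements on the series, on what has been measured and on what is new or still open speak of the compounds shown alone.

In a functional assay on HL-60 cells (Homo sapiens) for activation, read by flow cytometry, with a stated time of 4 days (a lower number here means that less compound is needed, a higher number that more compound is needed for the effect), compound 1 (`COc1ccc(-n2cnc3cnc(-c4ccccc4)cc32)cc1OC`) gives 1600 nM while compound 2 (`COc1ccc(-n2cnc3cnc(-c4ccccc4C)cc32)cc1OC`) gives 69 nM and compound 3 (`COc1ccc(-n2cnc3cnc(-c4ccc(F)cc4C)cc32)cc1OC`) gives 15 nM as the lowest of the three numbers. Compound 4 (`COc1ccc(-n2cnc3cnc(-c4ccc(F)cc4OC)cc32)cc1OC`) is not yet measured and carries methoxy in place of methyl on an aromatic carbon. Among the compounds with values here, two measured steps bear on it: the large step (a 23-fold lower number from compound 1 to compound 2 (1.37 log units; beyond the scatter)) for methyl in place of hydrogen on that carbon and the modest step (a 4.6-fold lower number from compound 2 to compound 3 (0.66 log units; beyond the scatter)) for fluoro in place of hydrogen, a fluoro that compound 4 keeps. Within the data shown here, no measured step exchanges methyl for methoxy, so only a small rise in the number is expected in this assay with no step beyond the scatter also possible. The estimated step is small (a 1.9-fold higher number from compound 3 to compound 4 (0.27 log units; within the scatter)). The estimated value for compound 4 is 28 nM with 8 nM to 100 nM as its expected range.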

Compound 4, half-maximal effective concentration: 35 nM
Compound 4: middle estimate off by 1.3-fold (0.10 log units), on the low side; the measured number falls inside the stated range.
By their numbers in this assay, from the lowest: compound 3; then compounds 4 and 2 (each within the scatter of the next); then compound 1.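

In this assay, this aromatic carbon, ortho to a large group, accepts methoxy as well as methyl, at a modest cost (a 2.3-fold higher number from compound 3 to compound 4 (0.37 log units; beyond the scatter)). The large gain over the plain phenyl of compound 1 therefore does not depend on methyl alone (a 46-fold lower number from compound 1 to compound 4 (1.66 log units; beyond the scatter)), and with fluoro kept, the methoxy compound stays within the scatter of compound 2 (a 2.0-fold lower number from compound 2 to compound 4 (0.29 log units; within the scatter)). No evidence on the source of the methyl-to-methoxy difference is available. Still open, going by these compounds, is how methoxy behaves here without the fluoro group. Also open, on these data alone, is whether ethyl, an amine or a longer chain is accepted on this carbon.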